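Bromo on the stilbene amide: working notes

The source may report more compounds than this note shows. Statements on the series, on what has been measured and on what is new or still open speak of the compounds shown alone.

Values in a functional assay on HUVEC cells (Homo sapiens) for inhibition, with a stated time of 4 days; a higher number here means a weaker inhibitor, a lower number a stronger inhibitor:
- Compound 1 `Cc1cc(OCc2cccc(C#N)c2)ccc1Cl`: 11000 nM
- Compound 2 `COc1ccc(C(=O)O)cc1COc1ccc(Cl)c(C)c1`: > 50000 nM, a limit and not a number
- Compound 3 `COc1ccc(C(N)=O)cc1/C=C/c1ccccc1`: 2400 nM

For the measured compounds named here, only two of these values are numbers. Compound 3 holds the lower of them at 2400 nM, and the gap to compound 1, which gives 11000 nM, lies beyond the scatter.

Compound 4 `COc1ccc(C(N)=O)cc1/C=C/c1ccc(Br)cc1` is next, with bromo in place of hydrogen on an aromatic carbon of a six-membered aromatic ring of carbon only, para to a large group (bromo in place of hydrogen on an aromatic carbon).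

Going by the values given here, no measured pair shows this change, so the expectation starts from compound 3 at 2400 nM. A small move to a lower number in this assay is expected, possibly none beyond the scatter. The expected step is a 1.4-fold lower number from compound 3 to compound 4 (0.15 log units; within the scatter). Compound 4 is estimated at 1700 nM, with an expected range of 500 nM to 6000 nM.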

Compound 4, half-maximal inhibitory concentration: 560 nM
Compound 4: the middle estimate sits 3.0-fold (0.48 log units) above what was measured, and the stated range covers the measured number.
By their numbers in this assay, from the lowest: compound 4; then compound 3; then compound 1. At a limit, above all of these: compound 2.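

In this assay, bromo in place of hydrogen on an aromatic carbon, para to a large group, gives a 4.3-fold lower number from compound 3 to compound 4 (0.63 log units; beyond the scatter). For the compounds shown here, this is the first single-place change, and it shows that this carbon takes a bromo with a move to a lower number beyond the scatter. Nothing in the data shown bears on why this step occurs.

From the compounds shown here alone, whether the move belongs to bromo itself remains open, since fluoro or an amine at this place would be needed for comparison. Going by these compounds, the effect of bromo on the other carbons of this ring also remains open.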